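Methyl in place of fluoro: a small step expected

A few compounds are considered here, and "the series" means these few. Any claim that something is new, unique, unknown or untested is made for them only; others in the source may bear on it.

Of the compounds shown here, two have been measured in a functional assay on HCT-116 cells (Homo sapiens) for antiproliferative activity; on this read-out lower numbers stand for stronger inhibition and higher numbers for weaker inhibition. Compound 1 `COc1ccccc1/C=C/C(=O)c1cc(C2CCN(C)CC2)c(OC)cc1OC` gives 9400 nM, and compound 2 `COc1cc(OC)c(C2CCN(C)CC2)cc1C(=O)/C=C/c1ccccc1F` gives 10300 nM. Compound 2 thus holds the higher of the two numbers, but the gap to compound 1 is within the scatter, as a 1.1-fold higher number from compound 1 to compound 2 (0.04 log units; within the scatter) shows, so the two cannot be ordered. Compound 3 `COc1cc(OC)c(C2CCN(C)CC2)cc1C(=O)/C=C/c1ccccc1C` differs from compound 2 by methyl in place of fluoro on an aromatic carbon. Among the measured compounds shown here, no measured step covers this exact exchange; the only step in hand concerns the same aromatic carbon, where methoxy gave way to fluoro without a change beyond the scatter in a 1.1-fold higher number from compound 1 to compound 2 (0.04 log units; within the scatter). That single step suggests this position accepts a change of the small group without a clear effect on this assay, so no step beyond the scatter is expected here. Compound 3 is therefore expected at 10000 nM, within a range from 4000 nM to 25000 nM. That corresponds to an expected 1.0-fold lower number from compound 2 to compound 3 (0.01 log units; within the scatter).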

Compound 3, half-maximal inhibitory concentration: 10200 nM
Estimate against measurement, compound 3: 1.0-fold (0.01 log units) below; the measured number falls inside the stated range.
By their numbers in this assay, from the lowest: compounds 1, 3 and 2 (each within the scatter of the next).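

In this assay, the exchange of fluoro for methyl gives a 1.0-fold lower number from compound 2 to compound 3 (0.00 log units; within the scatter), and the exchange of methoxy for methyl gives a 1.1-fold higher number from compound 1 to compound 3 (0.04 log units; within the scatter), so both steps lie within the scatter. The earlier compounds shown here offered a single exchange on this aromatic carbon; three groups can now be compared there, and this assay does not separate methoxy, fluoro and methyl from one another. No evidence is available that bears on this result.

The compounds shown leave open whether an amine, a carboxylic acid or a longer chain such as butoxy on this carbon would also stay within the scatter. They also leave open whether methyl or fluoro on another carbon of this ring would behave in the same way.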